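The compounds below may be only part of what the source reports. "The series", "measured", "known", "first", "only" and "open" are said of these compounds alone.

Working notes on the series. The three measured compounds share a core in which a five-membered lactam ring bears an exocyclic double bond to a second ring: compound 1 `O=C1Nc2ccccc2/C1=C1/Cc2ccccc2C1=O`, compound 2 `O=C1NC(=O)/C(=C2/C(=O)Nc3ccccc32)N1` and compound 3 `O=C1NC(=S)N/C1=C1\C(=O)Nc2ccccc21`. All three were tested in a functional assay on OE21 cells (Homo sapiens) for antiproliferative activity, read by MTT assay, with a stated time of 72 h; a higher number here means a weaker inhibitor, a lower number a stronger inhibitor. Compound 1 gives 25100 nM; compound 2 gives 52300 nM; compound 3 gives 38700 nM. The number for compound 3 lies with those of compound 1 and compound 2, the gap to compound 2 and the gap to compound 1 each within the usual scatter, so the three compounds cannot be separated on this assay.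

The next compound, compound 4 `O=C1NC(=S)N/C1=C1\C(=O)Nc2c(Br)cccc21`, keeps the whole of compound 3 and differs in one place: bromo in place of hydrogen on an aromatic carbon. For the measured compounds named here, no measured pair shows what such a change does here, so nothing measured supports a step of any size in either direction. With the three measured numbers sitting so close, the step from compound 3 to compound 4 is expected to be small, a slight move toward a lower number at most, and not clearly beyond the scatter: a 1.5-fold lower number from compound 3 to compound 4 (0.19 log units; within the scatter). Compound 4 is therefore estimated in this assay at 25000 nM, within a range of 8000 nM to 80000 nM.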

Compound 4, half-maximal inhibitory concentration: 20200 nM
Estimate against measurement, compound 4: 1.2-fold (0.09 log units) above; the range from low to high includes it.
By their numbers in this assay, from the lowest: compounds 4, 1, 3 and 2 (each within the scatter of the next, the first and the last beyond it).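

In this assay, for the compounds shown here, bromo in place of hydrogen on an aromatic carbon, ortho to a fused ring and meta to a fused ring, gives a 1.9-fold lower number from compound 3 to compound 4 (0.28 log units; within the scatter) and supplies the only single-place step so far. This position on the six-membered aromatic ring of carbon only therefore accepts bromo, with compound 4 remaining within the scatter of compound 3, and this one pair shows no clear gain or loss from the substitution. No available evidence bears on the reason for this result.

Still open, as far as these compounds go, is whether a different group on this same carbon, such as an amine, a carboxylic acid, a methoxy group or a longer chain, would give a step beyond the scatter, and whether bromo on the other aromatic carbons of this ring would behave as it does here. Also open, from the compounds shown here alone, is whether the same bromo change would give a comparable step on the core of compound 1 or of compound 2, since a single pair on the core of compound 3 cannot show how far the result carries.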